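The source may hold more compounds than are shown below. What is called first, only, known or untested is meant among the compounds shown, and "the series" means these compounds.

Of the compounds shown here, two have so far been measured in an assay on cells for inhibition of cytochrome P450 11B2, mitochondrial (Homo sapiens), read by HPLC, with a stated time of 90 min; a lower number here means a stronger inhibitor, a higher number a weaker inhibitor. Compound 1, `Fc1ccc2nc(-c3cn[nH]c3)n(C3CC3)c2c1`, gives 782 nM in this assay. Compound 2, `CCc1ncncc1-c1nc2cc(F)c(F)cc2n1C1CC1`, gives 8 nM in this assay, the lower of the two values, with the gap to compound 1 lying beyond the usual scatter. Compound 3, `CNc1ncncc1-c1nc2cc(F)c(F)cc2n1C1CC1`, differs from compound 2 by one change: methylamino in place of ethyl on an aromatic carbon. Going by the values given here, no measured pair shows this exchange, so its effect is open; a modest weakening, rather than a gain, is expected, a 2.5-fold higher number from compound 2 to compound 3 (0.40 log units; beyond the scatter). Compound 3 is therefore estimated at 20 nM, with a range from 5 nM to 80 nM.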

Compound 3, half-maximal inhibitory concentration: < 2 nM
Compound 3 ended at the assay's limit; the forecaster's own chance of this, stated with the estimate: 2%; middle value at least 10-fold (1.00 log units) away from the limit.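

Methylamino in place of ethyl on this aromatic carbon, next to the ring nitrogen, gives an at least 4.0-fold lower number from compound 2 to compound 3 (0.60 log units; beyond the scatter) in this assay. The position therefore tolerates a group with a hydrogen-bond donor and a hydrogen-bond acceptor, and the exchange brings a gain rather than a loss. The full size of this step stays unknown, because compound 3 stands at a limit of the assay rather than at a number: the limit of < 2 nM in this assay, at which 1 of the 3 values shown sits.

Going by these compounds, whether a plain amine, dimethylamino or a longer chain such as propylamino would hold this strength at the same position remains open.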